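Working notes: from compound 2 to compound 4

A few compounds are considered here, and "the series" means these few. Any claim that something is new, unique, unknown or untested is made for them only; others in the source may bear on it.

In a physicochemical assay for acid dissociation, read by spectrophotometry, compound 2 `CCOc1cc(CN2CCC(NC(=O)c3cncc(C)c3)CC2)ccc1C` gives 8.08 and compound 3 `CCOc1cc(CN2CCC(NC(=O)c3cncc(C)c3)CC2)ccc1-c1ccc(F)cc1` gives 7.87, so the two numbers available lie within the scatter of each other. For compound 1 `CCOc1cc(CN2CCC[C@H](NC(=O)c3cncc(C)c3)CC2)ccc1Cl` the entry reads "not determined" (no result reported), which leaves it out of any comparison.

Compound 4 `CCOc1cc(CN2CCC(NC(=O)c3ccc(N)nc3)CC2)ccc1C` carries one change from compound 2: 6-aminopyridin-3-yl in place of 5-methylpyridin-3-yl on a carbonyl carbon. In words, this is 6-aminopyridin-3-yl in place of 5-methylpyridin-3-yl on a carbonyl carbon.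

Among the measured compounds shown here, only one measured step exists, a number 0.21 log units lower from compound 2 to compound 3 (within the scatter). It replaces methyl with 4-fluorophenyl on an aromatic carbon and leaves the group on the carbonyl carbon untouched. For the measured compounds named here, no measured step changes that group, so the guidance is indirect and the range is kept wide.

In this assay the estimated step is a number 0.02 log units higher from compound 2 to compound 4 (within the scatter), which is expected to stay within the scatter, with a higher read-out expected no more than a lower one. For compound 4 the expected value is 8.1, with an estimated range of 7.7 to 8.5.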

Compound 4, acid dissociation constant: 8.27
Compound 4: the middle estimate sits 0.17 log units below what was measured, and the stated range covers the measured number.
By their numbers in this assay, from the lowest: compounds 3, 2 and 4 (each within the scatter of the next, the first and the last beyond it).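

Among the compounds shown here, the group on the carbonyl carbon is varied here for the first time. In this assay, 6-aminopyridin-3-yl in place of 5-methylpyridin-3-yl gives a step that stays within the scatter (a number 0.19 log units higher from compound 2 to compound 4 (within the scatter)), so this exchange, which brings one more hydrogen-bond donor and one more hydrogen-bond acceptor, leaves the read-out indistinguishable from that of the parent. Nothing available bears on why the step stays this small.

One exchange at this position cannot show whether the group on the carbonyl carbon ever matters to this read-out. From the compounds shown here alone, it remains open whether a group carrying a carboxylic acid or a dimethylamino group at this same place would also stay within the scatter of compound 2.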